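Stripping an Isopropyl from a Ring Nitrogen

This account rests on a few compounds, and the source may have more. Where it says the series, first, only, none or still open, it means among the compounds named here.

Of the compounds shown here, three have been measured in an assay on cell membranes for displacement of a labelled ligand from Adrenergic receptor alpha-1 (Rattus norvegicus); a higher number here means a weaker inhibitor, a lower number a stronger inhibitor. Compound 1 `Cc1ccc2c(C3CCN(CCN4CCNC4=O)CC3)cn(-c3ccc(F)cc3)c2c1` gives 24 nM, compound 2 `O=C1NCCN1CCN1CCC(c2cn(-c3ccc(F)cc3)c3cc(F)ccc23)CC1` gives 2.2 nM, and compound 3 `CC(C)c1ccc2c(C3CCN(CCN4CCN(C(C)C)C4=O)CC3)cn(-c3ccc(F)cc3)c2c1` gives 730 nM, the highest of the three numbers; compound 1 is its nearest neighbour and compound 2 the furthest. Among the compounds with values here, the only measured step, an 11-fold lower number from compound 1 to compound 2 (1.04 log units; beyond the scatter), concerns an aromatic change and does not bear directly on the change considered here. Compound 4 `CC(C)c1ccc2c(C3CCN(CCN4CCNC4=O)CC3)cn(-c3ccc(F)cc3)c2c1` is made from compound 3 by hydrogen in place of isopropyl on an amide-type nitrogen in a ring. Within the data shown here, no measured pair isolates this change, but compounds 1 and 2 both carry a hydrogen at that ring nitrogen and show far lower numbers than compound 3. A large fall in the number is therefore expected, an 18-fold lower number from compound 3 to compound 4 (1.26 log units; beyond the scatter). Compound 4 is estimated at 40 nM, within a range from 10 nM to 200 nM.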

Compound 4, half-maximal inhibitory concentration: 250 nM
Compound 4: the middle estimate sits 6.3-fold (0.80 log units) below what was measured; the measured number lies above the stated range.
By their numbers in this assay, from the lowest: compound 2; then compound 1; then compound 4; then compound 3.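

In this assay the isopropyl on this ring nitrogen turns out to matter only modestly, with a 2.9-fold lower number from compound 3 to compound 4 (0.47 log units; beyond the scatter) as its removal leaves the rest of the molecule unchanged. The aromatic carbon weighs more in these compounds, with isopropyl in place of methyl giving a 10-fold higher number from compound 1 to compound 4 (1.02 log units; beyond the scatter) and isopropyl in place of fluoro giving a 110-fold higher number from compound 2 to compound 4 (2.06 log units; beyond the scatter) as steps labelled large. Nothing measured here explains these differences.

From the compounds shown here alone, whether a smaller ethyl or a cyclopropyl on the ring nitrogen would sit closer to hydrogen or to isopropyl remains open. So does whether removing the isopropyl from the ring nitrogen gives a step of similar size when methyl or fluoro occupies the aromatic carbon.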